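Swapping the amine for dimethoxyphenyl on the ketone

The source may report more compounds than this note shows. Statements on the series, on what has been measured and on what is new or still open speak of the compounds shown alone.

Measured compounds:
compound 1 `COc1cc(-c2cc(/C=C/C(=O)c3ccc(N)cc3)[nH]n2)cc(OC)c1OC` gives 2750 nM
compound 2 `COc1ccc(-c2cc(/C=C/C(=O)c3ccc(N)cc3)[nH]n2)cc1OC` gives 5310 nM
compound 3 `COc1ccc(-c2cc(/C=C/C(=O)c3cc(OC)c(OC)c(OC)c3)[nH]n2)cc1OC` gives 2260 nM

These three compounds were tested in a functional assay on SR cells (Homo sapiens) for inhibition, read by sulforhodamine B assay, with a stated time of 48 h; a higher number here means a weaker inhibitor of growth, a lower number a stronger inhibitor of growth. Among the measured values compound 1 stands second highest; its nearest neighbour is compound 3, and the gap to compound 2 is also small, so all three sit within the usual scatter of one another. Within the data shown here, the one measured step between near-identical structures, a 1.9-fold higher number from compound 1 to compound 2 (0.29 log units; within the scatter), stays within the scatter as well.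

Compound 4 `COc1ccc(C(=O)/C=C/c2cc(-c3cc(OC)c(OC)c(OC)c3)n[nH]2)cc1OC` has not yet been measured. It differs from compound 1 in one place: 3,4-dimethoxyphenyl in place of 4-aminophenyl on a carbonyl carbon. Among the measured compounds shown here, no measured step covers this exact change. The closest hint comes from compound 2 and compound 3, which differ only in the group on the carbonyl carbon: in this assay compound 2 gives 5310 nM and compound 3 gives 2260 nM, a difference that itself barely exceeds the scatter. A similar, modest move toward a lower number is therefore expected, if any. For compound 4 the estimate is 2000 nM, with a range from 700 nM to 6000 nM, meaning an expected step of a 1.4-fold lower number from compound 1 to compound 4 (0.14 log units; within the scatter).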

Compound 4, concentration for total growth inhibition: > 100000 nM
Compound 4: a limit, no number (the forecaster's own chance of this, stated with the estimate: 5%); middle value at least 50-fold (1.69 log units) from the limit.
By their numbers in this assay, from the lowest: compounds 3, 1 and 2 (each within the scatter of the next, the first and the last beyond it). At a limit, above all of these: compound 4.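

Changing the group on the carbonyl carbon from 4-aminophenyl to 3,4-dimethoxyphenyl gives an at least 36-fold higher number from compound 1 to compound 4 (1.56 log units; beyond the scatter), so this position responds strongly to the group it carries. Among these compounds, the only earlier step between near-identical compounds, a 1.9-fold higher number from compound 1 to compound 2 (0.29 log units; within the scatter), involved a methoxy on an aromatic carbon and stayed within the scatter, so it gave no sign of a change this large. In this assay, the result for compound 4 is a limit of the assay and not a number: the limit of > 100000 nM in this assay, at which 1 of the 4 values shown sits.

The compounds shown cannot separate the loss of the amine from the arrival of the two methoxy groups, and the true value of compound 4 remains unknown. Plain phenyl or 4-hydroxyphenyl on the same carbonyl carbon would help to tell these two parts of the change apart.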